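Removing the amide substituent: a primary amide on the shared core

A few compounds are considered here, and "the series" means these few. Any claim that something is new, unique, unknown or untested is made for them only; others in the source may bear on it.

Of the compounds shown here, two built on the same core have been measured in an assay on isolated protein for inhibition of mitogen-activated protein kinase kinase kinase kinase 4 (Homo sapiens), read by Z'-LYTE; a higher number here means a weaker inhibitor, a lower number a stronger inhibitor. Compound 1 `N#CCNC(=O)c1cnc(N)c2cc(-c3cccc(F)c3)ccc12` gives 46 nM. Compound 2 `CC(=O)N1CC(NC(=O)c2cnc(N)c3cc(-c4cccc(F)c4)ccc23)C1` gives 32 nM; the two numbers lie within the scatter of each other, so neither compound can be called the stronger inhibitor. Among the measured compounds shown here, the only step measured so far, a 1.4-fold lower number from compound 1 to compound 2 (0.16 log units; within the scatter), shows that swapping one group on the amide-type nitrogen for another left the number essentially unchanged.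

Compound 3 `NC(=O)c1cnc(N)c2cc(-c3cccc(F)c3)ccc12` has not been measured. It differs from compound 2 by hydrogen in place of 1-acetylazetidin-3-yl on an amide-type nitrogen. For the measured compounds named here, no measured step strips the amide nitrogen bare in this way, so the comparison rests only on the one exchange on that nitrogen, which was within the scatter. Compound 3 is therefore expected to show a 1.3-fold higher number from compound 2 to compound 3 (0.10 log units; within the scatter) in this assay, with no change beyond the scatter. Compound 3 is estimated at 40 nM, with a range from 12 nM to 130 nM.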

Compound 3, half-maximal inhibitory concentration: 18 nM
The estimate for compound 3 lay 2.2-fold (0.35 log units) above the measured number; low and high end bracket the measured number.
By their numbers in this assay, from the lowest: compounds 3, 2 and 1 (each within the scatter of the next, the first and the last beyond it).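

In this assay, taking the whole 1-acetylazetidin-3-yl group off the amide-type nitrogen gives a 1.8-fold lower number from compound 2 to compound 3 (0.25 log units; within the scatter) and so does not lift the number; this group of 7 heavy atoms, with its four-membered ring, is not required for inhibition at this level. Among the compounds shown here, replacing cyanomethyl with hydrogen at the same nitrogen gives a 2.6-fold lower number from compound 1 to compound 3 (0.41 log units; beyond the scatter) and is the only step at this nitrogen that clears the scatter, though modestly. No measurement shown here accounts for this difference.

The compounds shown leave open how a small group such as methyl, or a longer chain ending in an amine or a carboxylic acid, would compare with hydrogen on this nitrogen. On these data alone, whether the same changes would give similar steps on a different core also remains unknown.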